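The compounds below may be only part of what the source reports. "The series", "measured", "known", "first", "only" and "open" are said of these compounds alone.

Measured in an ADME assay on HepG2 cells (Homo sapiens) for cytotoxicity, read by MTT assay, with a stated time of 48 h; on this read-out lower numbers stand for stronger inhibition and higher numbers for weaker inhibition:

Compound 1 `CC(C)CN1C(=O)/C(=C/c2ccc(Cl)cc2)S/C1=N\c1ccccc1` gives "not determined" (no result reported)
Compound 2 `CC(C)CN1C(=O)/C(=C/c2ccccc2C(F)(F)F)S/C1=N\c1ccccc1` gives "not determined" (no result reported)
Compound 3 `CC(C)CN1C(=O)/C(=C/c2ccc(N(C)C)cc2)S/C1=N\c1ccccc1` gives > 100000 nM

Going by the values given here, compounds 1 and 2 have no reported result, so the series offers no measured step between compounds. Compound 3 has only a limit and no single number, namely > 100000 nM in this assay. Among the compounds with values here, this is the one reading available: the limit of > 100000 nM in this assay, at which 1 of the 3 values shown sits.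

The next compound to be tested is compound 4 `CC(C)CN1C(=O)/C(=C/c2ccc([N+](=O)[O-])cc2)S/C1=N\c1ccccc1`. It carries nitro in place of the dimethylamino of compound 3, on an aromatic carbon of a six-membered aromatic ring of carbon only, para to a large group (nitro in place of dimethylamino on an aromatic carbon). Within the data shown here, with no measured step to draw on, the expectation rests on the limit of compound 3 alone. A modest change, if any, toward stronger inhibition is expected, estimated as an at least 1.4-fold lower number from compound 3 to compound 4 (0.15 log units; that floor lies within the scatter) in this assay, and the result may again be only a limit. Compound 4 is expected at 70000 nM within an estimated range of 20000 nM to 200000 nM on this read-out.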

Compound 4, half-maximal inhibitory concentration: > 100000 nM
Compound 4: no number, only a limit; the forecaster's own chance of this, stated with the estimate: 45%; middle value at least 1.4-fold (0.15 log units) from the limit.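

No step can be read from compound 3 to compound 4, since each gives only a limit and no number: the limit of > 100000 nM in this assay, at which 2 of the 4 values shown sit. The compounds shown leave open whether 4-(dimethylamino)phenyl and 4-nitrophenyl differ at all on this read-out, and at what concentration either compound would reach half-maximal inhibition.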